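The compounds below may be only part of what the source reports. "The series", "measured", "known", "first", "only" and "open" are said of these compounds alone.

Compound 1 `OCc1cn(Cc2cccc(F)c2)c2ccccc12`: > 31600 nM
Compound 2 `OCc1cn(Cc2cccc(Br)c2)c2ccccc12`: > 31600 nM
Compound 3 `OCc1cn(Cc2ccc(Br)c(Br)c2)c2ccccc12`: not yet measured

In an ADME assay on T29 cells (Homo sapiens) for cytotoxicity, read by sulforhodamine B assay, with a stated time of 3 days (on this read-out higher numbers stand for weaker inhibition and lower numbers for stronger inhibition), compound 2 gives > 31600 nM, which is a limit and not a number. Compound 1 gives > 31600 nM, also a limit. Both compounds therefore stand at the limit of > 31600 nM in this assay, at which 2 of the 2 values shown sit.

Compound 3 differs from compound 2 by bromo in place of hydrogen on an aromatic carbon. Among the measured compounds shown here, the only measured step that bears on this change is a step that the two limits leave unreadable from compound 1 to compound 2, with bromo in place of fluoro on an aromatic carbon. It offers no size to carry over, so no definite shift is expected in this assay, and another limit is the likeliest result. A number, if one appears, could well fall on the side of stronger inhibition. Compound 3 is estimated at 31600 nM, with an expected range of 12000 nM to 60000 nM. This estimate corresponds to an expected a number no higher from compound 2 to compound 3 (the limit leaves the size open).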

Compound 3, half-maximal inhibitory concentration: > 31600 nM
Compound 3: no number, only a limit; the forecaster's own chance of this, stated with the estimate: 75%; the middle value lies on the limit itself.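

Compound 2 and compound 3 each give only a limit in this assay, so no step between them can be read: the limit of > 31600 nM in this assay, at which 3 of the 3 values shown sit.

The compounds shown leave open where the true values of compound 1, compound 2 and compound 3 lie, and whether bromo in place of hydrogen shifts them at all.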